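A Thiophene Swap on the Shared Core, Estimated

A few compounds are considered here, and "the series" means these few. Any claim that something is new, unique, unknown or untested is made for them only; others in the source may bear on it.

Three compounds carrying a hydroxyphenyl group, a chlorophenyl group and a third aromatic ring on a shared core have been measured in a functional assay on T47D cells (Homo sapiens) for cytotoxicity, read by CCK-8 assay and cell counting, with a stated time of 2 days; a higher number here means a weaker inhibitor, a lower number a stronger inhibitor. Compound 1 `Oc1cccc(-c2cc(-c3ccccc3)nc(-c3ccccc3Cl)c2)c1` gives 2920 nM, compound 3 `Oc1ccc(-c2cc(-c3ccccc3)nc(-c3cccc(Cl)c3)c2)cc1` gives 4790 nM, and compound 2 `Oc1ccc(-c2cc(-c3ccsc3)nc(-c3cccc(Cl)c3)c2)cc1` gives 7390 nM. Compound 2 arises from compound 3 by one change, (thiophen-3-yl in place of phenyl on an aromatic carbon), and that step is a 1.5-fold higher number from compound 3 to compound 2 (0.19 log units; within the scatter). The difference between the cores of compound 1 and compound 3 is not broken down here. Compound 4 `Oc1cccc(-c2cc(-c3ccsc3)nc(-c3ccccc3Cl)c2)c1` has not yet been measured; it arises from compound 1 by thiophen-3-yl in place of phenyl on an aromatic carbon. Among the compounds with values here, this is the same kind of change as the one from compound 3 to compound 2, but the surroundings differ: in compound 1 the place is meta to a 2-chlorophenyl group and meta to a 3-hydroxyphenyl group, whereas in compound 3 it is meta to a 3-chlorophenyl group and meta to a 4-hydroxyphenyl group. Compound 4 is expected to show a 1.5-fold higher number from compound 1 to compound 4 (0.19 log units; within the scatter) because a 1.5-fold higher number from compound 3 to compound 2 (0.19 log units; within the scatter) was seen for the same kind of change. In this assay compound 4 is therefore estimated at 4500 nM, with a likely range from 2000 nM to 10000 nM.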

Compound 4, half-maximal inhibitory concentration: 2440 nM
The estimate for compound 4 lay 1.8-fold (0.27 log units) above the measured number, within the range that was stated.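

In this assay, placing thiophen-3-yl where phenyl stood on the core of compound 1 gives a 1.2-fold lower number from compound 1 to compound 4 (0.08 log units; within the scatter). Set beside the earlier step, the same change gives results on the two cores that cannot be told apart: the same change on two cores in this assay, a 1.5-fold higher number (0.19 log units; within the scatter) from compound 3 to compound 2 and a 1.2-fold lower number (0.08 log units; within the scatter) from compound 1 to compound 4, 1.8-fold (0.27 log units) apart, within the scatter of two such steps. This shows that, for these two pairs, exchanging phenyl for thiophen-3-yl leaves each step within the scatter on either core, but it does not show that the two cores respond identically or that any other core in the series would behave the same way.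

The compounds shown also leave open how much the chlorophenyl and hydroxyphenyl groups contribute separately, since the two cores differ in the placement of both at once. From the compounds shown here alone, in this place on the shared core, only phenyl and thiophen-3-yl appear, so it remains open what an amine-bearing ring, a carboxylic acid or a longer chain would do there.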